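The compounds below may be only part of what the source reports. "The series", "measured", "known", "first", "only" and "open" are said of these compounds alone.

Measured so far in a functional assay on Caco-2 cells (Homo sapiens), read by MTT assay, with a stated time of 48 h; on this read-out higher numbers stand for weaker inhibition and lower numbers for stronger inhibition:
- compound 1 `CCN(CC)CCNC(=O)c1ccc(C(CC)(CC)c2ccc(OCC(=O)C(C)(C)C)c(C)c2)n1CC`: 1600 nM
- compound 2 `CCn1c(C(=O)NCCN(C)C)ccc1C(CC)(CC)c1ccc(OCC(=O)C(C)(C)C)c(C)c1`: 1600 nM

Going by the values given here, compound 2 stands level with compound 1, its only measured neighbour. Next comes compound 3 `CCn1c(C(=O)NCCCN(C)C)ccc1C(CC)(CC)c1ccc(OCC(=O)C(C)(C)C)c(C)c1`, which differs from compound 2 by (dimethylamino)methyl in place of dimethylamino on a saturated chain carbon, two bonds along the chain from an amide-type nitrogen. Cut one bond further out, the same difference reads 2-(dimethylamino)ethyl to 3-(dimethylamino)propyl. Among the compounds with values here, the one measured step at this place is no change at the digits printed from compound 1 to compound 2 (within the scatter), and it lies within the scatter. That step swaps the groups on the amino nitrogen and leaves the chain as it is, so it bears on the new change only indirectly. Within the data shown here, no measured step lengthens the chain. No shift beyond the scatter is therefore expected in this assay, and no direction can be argued. The expected step is no change at the digits printed from compound 2 to compound 3 (within the scatter). For compound 3 the estimated value is 1600 nM, with an expected range of 700 nM to 3500 nM.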

Compound 3, half-maximal inhibitory concentration: 1400 nM
Compound 3: the middle estimate sits 1.1-fold (0.06 log units) above what was measured, and the stated range covers the measured number.
By their numbers in this assay, from the lowest: compounds 3, 1 and 2 (each within the scatter of the next).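

In this assay, the change from 2-(dimethylamino)ethyl to 3-(dimethylamino)propyl gives a 1.1-fold lower number from compound 2 to compound 3 (0.06 log units; within the scatter) and so adds a measured chain-length step at this position, where only a change of the groups on the amino nitrogen had been read before. The change of chain and nitrogen groups together gives a 1.1-fold lower number from compound 1 to compound 3 (0.06 log units; within the scatter) and thus also stays within the scatter in this assay. No supporting data on these groups are available to explain this result.

From the compounds shown here alone, whether a longer chain such as 4-(dimethylamino)butyl would stay level with these compounds remains open. The same holds for a pyrrolidine or morpholine in place of dimethylamino, and for a carboxylic acid in place of the amine.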